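The compounds below may be only part of what the source reports. "The series", "measured", "known", "first", "only" and "open" are said of these compounds alone.

Measured compounds in an ADME assay on Vero cells (Chlorocebus sabaeus) for cytotoxicity, read by luminescence, with a stated time of 2 days; on this read-out higher numbers stand for lower toxicity in this test and lower numbers for higher toxicity in this test:
Compound 1, `CCc1nc2ccccc2n1CCCOc1ccccc1`: compound 1 gives > 50 uM, a limit of the assay.
Compound 2, `Cc1nc2ccccc2n1CCCCOc1ccccc1`: compound 2 gives > 50 uM, also a limit of the assay.
Compound 3, `CCc1nc2ccccc2n1CCCCOc1cccc(Cl)c1`: compound 3 gives 22 uM.

Within the data shown here, compound 3 thus carries the only actual number in this assay; the other two results sit at the limit, as the limit of > 50 uM in this assay, at which 2 of the 3 values shown sit, records. Compound 4, `CCc1nc2ccccc2n1CCCCOc1ccc(C#N)cc1`, differs from compound 3 by 4-cyanophenyl in place of 3-chlorophenyl on an oxygen on a saturated carbon. Among the measured compounds shown here, no measured step connects the pair. Compounds 1 and 2 both lack the chlorine and both reach the limit, so the expectation is that compound 4 moves back towards that limit, a modest rise in this assay of about a 2.0-fold higher number from compound 3 to compound 4 (0.31 log units; beyond the scatter). Compound 4 is estimated at 45 uM, in the range 18 uM to 110 uM, with a fair chance that only a limit is reported.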

Compound 4, half-maximal toxic concentration: 27 uM
Compound 4: the middle estimate sits 1.7-fold (0.22 log units) above what was measured; the measured number falls inside the stated range.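

In this assay, the exchange on an oxygen on a saturated carbon gives a 1.2-fold higher number from compound 3 to compound 4 (0.09 log units; within the scatter), so 4-cyanophenyl and 3-chlorophenyl read alike here. Compound 4 carries an actual number, so a measurable reading at this position does not depend on the chlorine. The limit stays with compound 1 and compound 2: the limit of > 50 uM in this assay, at which 2 of the 4 values shown sit.

Open, from the compounds shown here alone, is how an unsubstituted phenyl would read on the core of compound 3. Also open, going by these compounds, is whether an amine or a carboxylic acid on that ring would move the number beyond the scatter.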